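Ring-Closed Peptide Antagonists: Growing the Side Chain

The source may report more compounds than this note shows. Statements on the series, on what has been measured and on what is new or still open speak of the compounds shown alone.

Measured so far:
compound 1, `CSCC[C@@H]1NC[C@@H](CC(C)C)NC(=O)CCNC(=O)[C@@H](Cc2ccccc2)NC(=O)[C@H](Cc2c[nH]c3ccccc23)NC(=O)[C@@H](CCC(N)=O)NC1=O`, 12.9 nM
compound 2, `CC(C)C[C@@H]1CN[C@@H](Cc2ccccc2)C(=O)N[C@H](CCC(N)=O)C(=O)N[C@@H](Cc2c[nH]c3ccccc23)C(=O)N[C@H](Cc2ccccc2)C(=O)NCCC(=O)N1`, 18.6 nM

In a functional assay (Cricetulus griseus) for antagonist activity at Substance-K receptor (Mesocricetus auratus) (on this read-out higher numbers stand for weaker binding and lower numbers for tighter binding), compound 2 gives 18.6 nM. Going by the values given here, its only neighbour is compound 1 at 12.9 nM, and a 1.4-fold higher number from compound 1 to compound 2 (0.16 log units; within the scatter) places the two within the scatter of each other. Compound 3, `CC(C)C[C@@H]1CN[C@@H](CCC(N)OCc2ccccc2)C(=O)N[C@H](CCC(N)=O)C(=O)N[C@@H](Cc2c[nH]c3ccccc23)C(=O)N[C@H](Cc2ccccc2)C(=O)NCCC(=O)N1`, carries 2-amino-2-(benzyloxy)ethyl in place of phenyl on a saturated chain carbon bound to a saturated ring carbon. Among the compounds with values here, the one measured step at this position, a 1.4-fold higher number from compound 1 to compound 2 (0.16 log units; within the scatter), is within the scatter, and no step covers an addition of this kind, so only a modest change is expected: a 1.6-fold higher number from compound 2 to compound 3 (0.21 log units; within the scatter). Compound 3 is therefore estimated at 30 nM, between 8 nM and 120 nM.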

Compound 3, dissociation constant: 2.19 nM
Estimate against measurement, compound 3: 14-fold (1.14 log units) above; the measured number lies below the stated range.
By their numbers in this assay, from the lowest: compound 3; then compounds 1 and 2 (each within the scatter of the next).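

In this assay, this position, a saturated chain carbon bound to a saturated ring carbon, now shows a step beyond the scatter: 2-amino-2-(benzyloxy)ethyl in place of phenyl gives an 8.5-fold lower number from compound 2 to compound 3 (0.93 log units; beyond the scatter) in this series. The other listed step, a 5.9-fold lower number from compound 1 to compound 3 (0.77 log units; beyond the scatter) in this series, is also beyond the scatter, whereas compound 1 and compound 2 had stayed within the scatter of each other. Nothing available gives a reason for these steps. The amine and the benzyloxy group enter together, so it remains open which of them accounts for the lower number. A plain benzyloxy chain without the amine, or an amine chain without the benzyloxy group, would separate the two.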